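Benzylamine series: bromo to chloro on the terminal ring

This account rests on a few compounds, and the source may have more. Where it says the series, first, only, none or still open, it means among the compounds named here.

Compound 3 `COc1cc(Oc2cccc(Nc3ccccc3)c2)cc(OC)c1CNCc1ccc(Br)cc1` gives 3520 nM in a functional assay on DLD-1 cells (Homo sapiens) for inhibition, read by MTT assay, with a stated time of 72 h (on this read-out lower numbers stand for stronger inhibition and higher numbers for weaker inhibition), the lowest of the two numbers recorded; the nearest is compound 2 `COc1ccc(CCCNCc2c(OC)cc(Oc3ccc(Nc4ccccc4)cc3)cc2OC)cc1`, which gives 4650 nM in this assay, a gap that lies within the scatter, so no order between the two can be claimed. Compound 1 `CCN1CCN(Cc2c(OC)cc(Oc3cccc(Nc4ccccc4)c3)cc2OC)CC1` gives only a limit in this assay, > 20000 nM, and no number (the limit of > 20000 nM in this assay, at which 1 of the 3 values shown sits). Going by the values given here, the one measured step is an at least 5.6-fold lower number from compound 1 to compound 3 (0.75 log units; beyond the scatter).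

Compound 4 `COc1cc(Oc2cccc(Nc3ccccc3)c2)cc(OC)c1CNCc1ccc(Cl)cc1` differs from compound 3 by chloro in place of bromo on an aromatic carbon. Among the compounds with values here, no measured step bears directly on this change; the step from compound 1 to compound 3 exchanges a far larger group and says nothing about the halogen on the aromatic carbon. The change here is a single-atom exchange, and in this assay a step of about a 1.1-fold higher number from compound 3 to compound 4 (0.06 log units; within the scatter) is expected, which is within the scatter. Compound 4 is therefore estimated at 4000 nM in this assay, with a range from 1800 nM to 9000 nM.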

Compound 4, half-maximal inhibitory concentration: 3740 nM
Compound 4: middle estimate off by 1.1-fold (0.03 log units), on the high side; the measured number falls inside the stated range.
By their numbers in this assay, from the lowest: compounds 3, 4 and 2 (each within the scatter of the next). At a limit, above all of these: compound 1.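

In this assay, the exchange of chloro for bromo on an aromatic carbon, para to a large group, gives a 1.1-fold higher number from compound 3 to compound 4 (0.03 log units; within the scatter), so the two halogens cannot be told apart at this position. The step away from 4-ethylpiperazin-1-yl holds with the chloro compound too, as an at least 5.3-fold lower number from compound 1 to compound 4 (0.72 log units; beyond the scatter), so it does not depend on bromo alone. The reference point for both steps is a limit and not a number: the limit of > 20000 nM in this assay, at which 1 of the 4 values shown sits.

On these data alone, what hydrogen, methoxy, trifluoromethyl or a carboxylic acid would give at this position stays open, since two halogens alone do not show whether any group here can move the number beyond the scatter. As far as these compounds go, it also stays open whether the same exchange would read alike on the shared core of compound 2, whose chain and ring attachment differ.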